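The source may report more compounds than this note shows. Statements on the series, on what has been measured and on what is new or still open speak of the compounds shown alone.

In a functional assay (aorta) with Rattus norvegicus as the target, in the presence of a further agent that is not named here (a lower number here means that less compound is needed, a higher number that more compound is needed for the effect), compound 1 `COC(=O)C1=C(C)N=C(C)/C(=C(/O)OC)C1c1ccccc1OCc1nonc1C` gives 41 nM, while compound 2 `COC(=O)C1=C(C)N=C(C)/C(=C(/O)OC)C1c1ccccc1OCc1nonc1C(N)=O` gives 970 nM, the higher of the two numbers. Compound 3 `COC(=O)C1=C(C)N=C(C)/C(=C(/O)OC)C1c1ccccc1OCc1no[n+]([O-])c1C(N)=O` differs from compound 2 by a group of 9 heavy atoms (3 carbon, 3 nitrogen, 3 oxygen; one five-membered aromatic ring with 3 hetero atoms) in place of a group of 8 heavy atoms (3 carbon, 3 nitrogen, 2 oxygen; one five-membered aromatic ring with 3 hetero atoms), on a saturated chain carbon bound to an oxygen on an aromatic ring; 4-carbamoyl-1,2,5-oxadiazol-3-yl leaves. Within the data shown here, the only measured step, a 24-fold higher number from compound 1 to compound 2 (1.37 log units; beyond the scatter), is large but replaces methyl with carbamoyl on an aromatic carbon. Among the measured compounds shown here, it shows that the number can move widely within this group, yet no measured step covers the present change. A moderate move to a lower number is therefore expected, with wide uncertainty. The estimated step is a 2.4-fold lower number from compound 2 to compound 3 (0.38 log units; beyond the scatter). For compound 3, the expected value is 400 nM, with an estimated range of 80 nM to 1800 nM.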

Compound 3, half-maximal effective concentration: 550 nM
Estimate against measurement, compound 3: 1.4-fold (0.14 log units) below, and the stated range covers the measured number.
By their numbers in this assay, from the lowest: compound 1; then compounds 3 and 2 (each within the scatter of the next).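

In this assay, the group with one further oxygen in place of 4-carbamoyl-1,2,5-oxadiazol-3-yl gives a 1.8-fold lower number from compound 2 to compound 3 (0.25 log units; within the scatter), so this change on a saturated chain carbon bound to an oxygen on an aromatic ring does not separate the two compounds. The large gap to the methyl compound remains, with a 13-fold higher number from compound 1 to compound 3 (1.13 log units; beyond the scatter). No measured evidence bears on either step.

Still open, on these data alone, is whether the further oxygen would matter with methyl on the ring. Also open, as far as these compounds go, is how a carboxylic acid or nitrile in place of the carbamoyl group would read in this assay.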